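This account rests on a few compounds, and the source may have more. Where it says the series, first, only, none or still open, it means among the compounds named here.

In a functional assay on Bel-7402 cells (Homo sapiens) for inhibition, read by MTT assay, with a stated time of 24 h, tested at 1 ug/mL (a higher number here means more inhibition of growth at the concentration tested, a lower number less inhibition of growth), compound 1 (`O=C(CCCCC1CCSS1)Nc1ccccc1Cl`) gives 5.33% and compound 2 (`O=C(CCCCC1CCSS1)Nc1ccc(Br)cn1`) gives 13.1%, so the two numbers lie within the usual scatter of each other and compound 1 cannot be separated from compound 2. Compound 3 (`O=C(CCCCC(S)CCS)Nc1ccccc1Cl`) differs from compound 1 by a group of 5 heavy atoms (3 carbon, 2 sulfur; no ring) in place of a group of 5 heavy atoms (3 carbon, 2 sulfur; one five-membered non-aromatic ring with 2 hetero atoms), on a saturated chain carbon, four bonds along the chain from a carbonyl carbon: a 1,3-disulfanylpropyl group, with no ring, stands on a saturated chain carbon, four bonds along the chain from a carbonyl carbon. Going by the values given here, no measured pair shows this change, so only a small upward step is expected, a number 5.7 percentage points higher from compound 1 to compound 3 (within the scatter), hardly beyond the scatter. Compound 3 is estimated at 11%, with an expected range from 2% to 26%.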

Compound 3, percent growth inhibition at one concentration: 3.08%
Beside the measured number, compound 3's estimate is 7.9 percentage points above it; low and high end bracket the measured number.
By their numbers in this assay, from the lowest: compounds 3, 1 and 2 (each within the scatter of the next).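

Replacing the five-membered ring of compound 1 with the open 1,3-disulfanylpropyl group, on a saturated chain carbon, four bonds along the chain from a carbonyl carbon, gives a number 2.3 percentage points lower from compound 1 to compound 3 (within the scatter) in this assay at this single concentration. At this position, the ring and the open form therefore cannot be separated, even though the entering group carries hydrogen-bond donors and the leaving group none. No measurement on hand speaks to the reason for this result.

On these data alone, whether an amine, a carboxylic acid or a longer chain at this position would move the number beyond the scatter remains open. So does whether the same change would behave alike on the core of compound 2.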